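Piperidine in Place of Dipropylamino on a Potent Core

The compounds below may be only part of what the source reports. "The series", "measured", "known", "first", "only" and "open" are said of these compounds alone.

The study compares three measured compounds that share a common core and differ only in the group on an aromatic carbon of a six-membered aromatic ring with 1 nitrogen. In a functional assay on CHO-K1 cells for antagonist activity at transient receptor potential cation channel subfamily V member 1 (Homo sapiens), read by FLIPR (a lower number here means a stronger inhibitor, a higher number a weaker inhibitor), compound 1 `CC(C(=O)NCc1ccc(C(F)(F)F)nc1NCc1ccc(Cl)cc1)c1ccc(NS(C)(=O)=O)c(F)c1` gives 65.7 nM. Compound 2 `CCCN(CCC)c1nc(C(F)(F)F)ccc1CNC(=O)C(C)c1ccc(NS(C)(=O)=O)c(F)c1` gives 0.2 nM, the lowest of the three numbers, and compound 3 `CCCCOC1CCN(c2nc(C(F)(F)F)ccc2CNC(=O)C(C)c2ccc(NS(C)(=O)=O)c(F)c2)CC1` gives 3.5 nM. The step of a 330-fold lower number from compound 1 to compound 2 (2.52 log units; beyond the scatter) is large, as is a 19-fold lower number from compound 1 to compound 3 (1.27 log units; beyond the scatter); between the two stronger compounds, an 18-fold higher number from compound 2 to compound 3 (1.24 log units; beyond the scatter).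

Compound 4 `CC(C(=O)NCc1ccc(C(F)(F)F)nc1N1CCC(CN(C)C)CC1)c1ccc(NS(C)(=O)=O)c(F)c1` is now considered. It differs from compound 2 in one place: 4-((dimethylamino)methyl)piperidin-1-yl in place of dipropylamino on an aromatic carbon. The measured step that bears most directly on this change is an 18-fold higher number from compound 2 to compound 3 (1.24 log units; beyond the scatter), where a six-membered non-aromatic ring with 1 hetero atom likewise replaced dipropylamino and the number rose. Compound 4 carries a different substituent on its ring, and nothing measured here shows how that substituent alone behaves, so the expectation rests on the step to compound 3. A step of similar size, upward, is therefore expected for compound 4: a 25-fold higher number from compound 2 to compound 4 (1.40 log units; beyond the scatter). Compound 4 is thus estimated at 5 nM, with a range from 1 nM to 30 nM.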

Compound 4, inhibition constant: 2.1 nM
Compound 4: middle estimate off by 2.4-fold (0.38 log units), on the high side; low and high end bracket the measured number.
By their numbers in this assay, from the lowest: compound 2; then compounds 4 and 3 (each within the scatter of the next); then compound 1.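

In this assay, the second ring-bearing group at this position also falls short of dipropylamino, with an 11-fold higher number from compound 2 to compound 4 (1.02 log units; beyond the scatter), so compound 2 remains ahead of both compounds in which a six-membered non-aromatic ring with 1 hetero atom stands on this aromatic carbon. Exchanging the substituent on that saturated ring, with (dimethylamino)methyl in place of butoxy, gives a 1.7-fold lower number from compound 3 to compound 4 (0.22 log units; within the scatter), so this assay does not separate the two substituents, even though they share little beyond their place on the ring. The gain over the (4-chlorobenzyl)amino compound also holds for this new group, with a 31-fold lower number from compound 1 to compound 4 (1.50 log units; beyond the scatter), which means that two differently substituted rings at this position both remain clearly stronger than compound 1.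

No measurement at hand accounts for any of these steps. On these data alone, how an unsubstituted piperidin-1-yl, a morpholin-4-yl or a dibutylamino group would read on this aromatic carbon stays open, and with it the question of whether the ring itself or its substituent sets the gap to compound 2.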